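Removing the oxetanyl from compound 1's pyrazole

The source may hold more compounds than are shown below. What is called first, only, known or untested is meant among the compounds shown, and "the series" means these compounds.

Compound 1, `Cc1nn(C2COC2)cc1Nc1nc(N)c2c(C#N)c(N3CCC[C@H]3C)n(C)c2n1`, carries an aminopyrazole attached through its ring nitrogen to an oxetan-3-yl group on a shared bicyclic core bearing a nitrile and a methylpyrrolidine. In an assay on isolated protein for inhibition of Leucine-rich repeat serine/threonine-protein kinase 2 variant G2019S (Homo sapiens), read by TR-FRET and LanthaScreen, with stated times of 50 min and 30 min, in the presence of a further agent that is not named here (a higher number here means a weaker inhibitor, a lower number a stronger inhibitor), compound 1 gives 25 nM, the lowest of the three numbers measured. Compound 2, `Cn1c(NCc2ccccc2)c(C#N)c2c(N)ncnc21`, lacks the pyrazole arm and instead carries a benzylamine; in this assay compound 2 gives 3530 nM. Compound 3, `C[C@H]1CCCN1c1c(C#N)c2c(N)ncnc2n1C`, keeps the methylpyrrolidine and nitrile but has no substituent at all at the position where compound 1 carries its pyrazole; in this assay compound 3 gives 3080 nM. Both gaps from compound 1 lie well beyond the usual scatter, so compound 1 stands as the strongest inhibitor of the three.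

The next compound, compound 4, `Cc1n[nH]cc1Nc1nc(N)c2c(C#N)c(N3CCC[C@H]3C)n(C)c2n1`, is the pyrazole of compound 1 stripped of one group: hydrogen in place of oxetan-3-yl on an aromatic nitrogen. For the measured compounds named here, no pair of measured compounds shows what this particular change does. The pyrazole arm itself plainly matters, as compound 3 shows, but the oxetane on its ring nitrogen is a smaller piece of that arm, and its loss is expected to cost only a modest step toward weaker inhibition, a 2.4-fold higher number from compound 1 to compound 4 (0.38 log units; beyond the scatter). Compound 4 is therefore estimated at 60 nM, within a range of 20 nM to 200 nM.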

Compound 4, half-maximal inhibitory concentration: 27 nM
Compound 4: middle estimate off by 2.2-fold (0.35 log units), on the high side, and the stated range covers the measured number.
By their numbers in this assay, from the lowest: compounds 1 and 4 (each within the scatter of the next); then compounds 3 and 2 (each within the scatter of the next).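

In this assay, hydrogen in place of oxetan-3-yl on the aromatic nitrogen gives a 1.1-fold higher number from compound 1 to compound 4 (0.03 log units; within the scatter), so at this position the two compounds cannot be told apart and the oxetan-3-yl ring makes no difference that this measurement can resolve. The low value therefore does not depend on that ring: compound 4, with only the 3-methyl-1H-pyrazol-4-yl arm, gives 27 nM, whereas compound 3, with no arm at all, gives 3080 nM. Nothing available here bears on why compound 1 and compound 4 read alike.

The compounds shown leave open whether this aromatic nitrogen would accept other groups equally well, such as a simple methyl, a longer alkyl chain, a piperidine carrying a free amine or a chain ending in a carboxylic acid, since oxetan-3-yl and hydrogen are the only two substituents seen there. They also leave open how much of the value rests on the methyl group of the pyrazole, which compound 1 and compound 4 share, and whether hydrogen or chlorine could stand in its place.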